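The compounds below may be only part of what the source reports. "The series", "measured", "known", "first", "only" and "open" are said of these compounds alone.

In a physicochemical assay for lipophilicity, read by HPLC, measured as chromatographic lipophilicity, at pH 7.4 (a higher number here means a more lipophilic compound, a lower number a more polar compound), compound 2 (`COc1cccc(NC(=O)c2nnn(Cc3ccc(C#N)cc3)c2N)c1`) gives 2.3 as the second highest of three numbers, with compound 1 (`COc1cccc(NC(=O)c2nnn(CC3CCN(C(C)=O)CC3)c2N)c1`) lower at 1.2 and compound 3 (`COc1cccc(NC(=O)c2nnn(C(C)c3ccc(C(C)(C)C)cc3)c2N)c1`) higher at 3.9 on the same scale. Compound 4 (`COc1cccc(NC(=O)c2nnn(Cc3cc(C)on3)c2N)c1`) has not yet been measured. It differs from compound 2 through 5-methyl-1,2-oxazol-3-yl in place of 4-cyanophenyl on a saturated chain carbon bound to an aromatic nitrogen with 5-methyl-1,2-oxazol-3-yl in place of 4-cyanophenyl on a saturated chain carbon bound to an aromatic nitrogen. Within the data shown here, one measured step bears on this place: a number 1.10 log units higher from compound 1 to compound 2 (beyond the scatter) on bringing in 4-cyanophenyl, a large step beyond the scatter. That same group now leaves and an aromatic ring remains, so a smaller fall is expected. The expected change is a number 0.50 log units lower from compound 2 to compound 4 (beyond the scatter) by this estimate. The estimated value for compound 4 is 1.8 with an expected range of 1.4 to 2.2 for this measurement.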

Compound 4, distribution coefficient: 2
Compound 4: middle estimate off by 0.20 log units, on the low side; low and high end bracket the measured number.
By their numbers in this assay, from the lowest: compound 1; then compounds 4 and 2 (each within the scatter of the next); then compound 3.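

In this assay, the change on a saturated chain carbon bound to an aromatic nitrogen gives a number 0.30 log units lower from compound 2 to compound 4 (within the scatter), so a five-membered aromatic ring with 2 hetero atoms does not separate from a six-membered aromatic ring of carbon only. Set against 1-acetylpiperidin-4-yl, 5-methyl-1,2-oxazol-3-yl gives a number 0.80 log units higher from compound 1 to compound 4 (beyond the scatter), so both aromatic groups now stand clear of that group. Nothing measured here accounts for either step. Open remains how a primary amine or a carboxylic acid would read at this place, and whether the methyl on the 1,2-oxazole matters.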